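The source may report more compounds than this note shows. Statements on the series, on what has been measured and on what is new or still open speak of the compounds shown alone.

In a functional assay on OVCAR cells (Homo sapiens) for cytotoxicity, read by sulforhodamine B assay, with a stated time of 48 h (on this read-out lower numbers stand for stronger inhibition and higher numbers for weaker inhibition), three compounds have been measured so far:
compound 1 `CC(=O)N1N=C(c2cccc3ccccc23)CC1c1cccc(Br)c1` gives 12300 nM;
compound 2 `CC(=O)N1N=C(c2cccc3ccccc23)CC1c1ccco1` gives 13000 nM;
compound 3 `O=CCN1N=C(c2ccc3ccccc3c2)CC1c1cccc(Br)c1` gives 10800 nM.

Compound 4 `O=CCN1N=C(c2ccc3ccccc3c2)CC1c1ccco1` has not yet been measured. Compounds 1 and 2 share a core and differ in one place: furan-2-yl in place of 3-bromophenyl on a saturated ring carbon. In this assay this change gave a 1.1-fold higher number from compound 1 to compound 2 (0.02 log units; within the scatter), a step too small to count as a real difference in potency. Compound 3 is built from the same atoms as compound 1 joined differently; the difference between the two cores is not broken down here, and the two values lie within the scatter of each other. From compound 3 to compound 4 the same kind of change is made: furan-2-yl in place of 3-bromophenyl on a saturated ring carbon. The surroundings of the place are not identical, though: in compound 1 the saturated ring carbon is next to the ring atom that bears an acetyl group, in compound 3 next to the ring atom that bears a formylmethyl group. Because a 1.1-fold higher number from compound 1 to compound 2 (0.02 log units; within the scatter) lay within the scatter, a similarly small step is expected here: a 1.1-fold higher number from compound 3 to compound 4 (0.05 log units; within the scatter). Compound 4 is therefore estimated to give about 12000 nM in this assay, most likely between 6000 nM and 24000 nM.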

Compound 4, half-maximal inhibitory concentration: 18000 nM
Estimate against measurement, compound 4: 1.5-fold (0.18 log units) below, and the stated range covers the measured number.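

In this assay, putting furan-2-yl in place of 3-bromophenyl gave a 1.7-fold higher number from compound 3 to compound 4 (0.22 log units; within the scatter), so on this second core the step again stays inside the normal spread of repeated measurements. Set beside the earlier step, the change looks much the same on both cores: the same change on two cores in this assay, a 1.1-fold higher number (0.02 log units; within the scatter) from compound 1 to compound 2 and a 1.7-fold higher number (0.22 log units; within the scatter) from compound 3 to compound 4, 1.6-fold (0.20 log units) apart, within the scatter of two such steps. This shows that in these two pairs the swap did not move the number beyond the scatter, but it does not show that the swap would be equally quiet on any other core, as two pairs cannot establish a general rule.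

The compounds shown leave open whether a different group on the same saturated ring carbon, such as an amine or a carboxylic acid, would move the number beyond the scatter. Also open, on these data alone, is what a longer chain in place of the acetyl or formylmethyl group would do when nothing else in the molecule changes.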